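Nitro in Place of Hydrogen on Compound 1

A few compounds are considered here, and "the series" means these few. Any claim that something is new, unique, unknown or untested is made for them only; others in the source may bear on it.

Among the compounds with values here, compound 1 `CC1=CC[C@H](C(C)(C)NC(=S)N/N=C/c2ccccc2)CC1` was tested in a functional assay on U-251 cells (Homo sapiens) for inhibition, read by sulforhodamine B assay, with a stated time of 48 h (on this read-out lower numbers stand for stronger inhibition of growth and higher numbers for weaker inhibition of growth), where compound 1 gives 71400 nM, the lowest of the two numbers known so far. Within the data shown here, its only measured neighbour is compound 2 `COc1ccc(/C=N/NC(=S)NC(C)(C)[C@H]2CC=C(C)CC2)cc1`, which carries a methoxy group on an aromatic carbon instead of a hydrogen. In this assay compound 2 gives 71900 nM. The step of a 1.0-fold higher number from compound 1 to compound 2 (0.00 log units; within the scatter) shows no difference beyond the scatter. Compound 3 `CC1=CC[C@H](C(C)(C)NC(=S)N/N=C/c2ccccc2[N+](=O)[O-])CC1` differs from compound 1 by nitro in place of hydrogen on an aromatic carbon. Among the measured compounds shown here, no measured step involves a nitro group, so the only guide is the methoxy step from compound 1 to compound 2, which stayed within the scatter. A similarly small step is therefore expected for compound 3, with no clear direction beyond the scatter, a 1.1-fold lower number from compound 1 to compound 3 (0.04 log units; within the scatter). Compound 3 is estimated at 65000 nM, with a range from 25000 nM to 160000 nM.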

Compound 3, concentration for total growth inhibition: > 100000 nM
Compound 3: a limit, no number; the forecaster's own chance of this, stated with the estimate: 25%; middle value at least 1.5-fold (0.18 log units) away from the limit.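

Compound 3 gives only a limit, not a number, in this assay: the limit of > 100000 nM in this assay, at which 1 of the 3 values shown sits. The nitro change therefore gives an at least 1.4-fold higher number from compound 1 to compound 3 (0.14 log units; that floor lies within the scatter), so only a lower bound on the step is known, and the true step may or may not lie beyond the scatter. Unlike the methoxy step, this result has no upper end, but it does show that nitro, ortho to a large group on the aromatic ring, gives no sign of stronger inhibition of growth than hydrogen.

The compounds shown leave open how far growth inhibition falls with nitro at this position. They also leave open whether a smaller group, such as fluoro, or an amine or a carboxylic acid on the same aromatic carbon would give a readable number.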